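Ether Oxygen in the Side Chain of Compound 1

A few compounds are considered here, and "the series" means these few. Any claim that something is new, unique, unknown or untested is made for them only; others in the source may bear on it.

Measured compounds:
Compound 1, `CCC/N=C1\S/C(=C\c2ccc(O)c(Cl)c2)C(=O)N1c1ccccc1C`: in a physicochemical assay for lipophilicity, read by HPLC, at pH 7.4 (on this read-out lower numbers stand for lower lipophilicity and higher numbers for higher lipophilicity), compound 1 gives 3.8.
Compound 2, `CCC/N=C1\S/C(=C\c2ccc(O)cn2)C(=O)N1c1ccccc1C`: in this assay compound 2 gives 3.
Compound 3, `CCC/N=C1\S/C(=C\c2ccc(O)c(Cl)c2)C(=O)N1c1ccccc1OC`: in this assay compound 3 gives 3.3.

Compound 1 stands highest of the three numbers in this assay. Its nearest neighbour is compound 3, with a number 0.50 log units lower from compound 1 to compound 3 (beyond the scatter), a change made on the aryl group of the core. Furthest away is compound 2, with a number 0.80 log units lower from compound 1 to compound 2 (beyond the scatter), a change on the other side of the core.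

Compound 4, `COCC/N=C1\S/C(=C\c2ccc(O)c(Cl)c2)C(=O)N1c1ccccc1C`, differs from compound 1 in one place: methoxy in place of methyl on a saturated chain carbon, two bonds along the chain from a double-bonded nitrogen. Read one bond further out, the propyl chain becomes a 2-methoxyethyl chain.

For the measured compounds named here, the step from compound 1 to compound 3 is the closest precedent, the same methyl-to-methoxy exchange though on an aromatic carbon, and it gave a modest lowering in this assay. The step from compound 1 to compound 2 is a larger change elsewhere, so it bears on compound 4 only loosely. A lowering beyond the scatter, of a size like or a little greater than the step from compound 1 to compound 3, is therefore expected for compound 4; compound 4 is estimated at 3.1, with a range from 2.6 to 3.5. This estimate means an expected step of a number 0.70 log units lower from compound 1 to compound 4 (beyond the scatter).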

Compound 4, distribution coefficient: 2.9
Compound 4: middle estimate off by 0.20 log units, on the high side; low and high end bracket the measured number.
By their numbers in this assay, from the lowest: compounds 4, 2 and 3 (each within the scatter of the next, the first and the last beyond it); then compound 1.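

Compound 4 is the only compound shown that varies the propyl chain, and the step of a number 0.90 log units lower from compound 1 to compound 4 (beyond the scatter) in this assay shows that this chain is a position where the read-out responds to a single change. The same exchange of methoxy for methyl had so far been seen only on an aromatic carbon, with the step of a number 0.50 log units lower from compound 1 to compound 3 (beyond the scatter), and it now gives a lower number on a saturated chain carbon as well, so both examples shown run in the same direction. Nothing available here explains why the number falls at either place.

The compounds shown leave open whether a 2-hydroxyethyl or a 2-aminoethyl chain on the same nitrogen would follow 2-methoxyethyl, and whether a longer chain such as 3-methoxypropyl would keep the lowering. They also leave open whether the 2-methoxyethyl chain would lower the number by a similar step when combined with the methoxy group of compound 3 or the 5-hydroxypyridin-2-yl group of compound 2.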